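A few compounds are considered here, and "the series" means these few. Any claim that something is new, unique, unknown or untested is made for them only; others in the source may bear on it.

Measured in a physicochemical assay for solubility; on this read-out lower numbers stand for lower solubility and higher numbers for higher solubility:
Compound 1 `CNC(=O)c1cc(C(=O)NC2CC2)cn(Cc2ccc(C)cc2)c1=O`: 24 ug/mL
Compound 2 `CNC(=O)c1cc(C(=O)NC2CC2)cn([C@H](C)c2ccccc2)c1=O`: >= 168 ug/mL (a limit)
Compound 3 `CNC(=O)c1ccc(=O)n(Cc2ccccc2)c1`: >= 108 ug/mL (a limit)

Compound 2 stands at >= 168 ug/mL, which is a limit and not a number. It is the highest figure shown, although it gives no exact value. Going by the values given here, compound 3 also gives only a limit, >= 108 ug/mL, and no measured step links it to the others.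

Compound 4 `CNC(=O)c1cc(C(=O)NC2CC2)cn(Cc2cccc(C)c2)c1=O` has 3-methylbenzyl in place of 1-phenylethyl on an aromatic nitrogen. Among the compounds with values here, the one measured step that bears on this change is an at least 7.0-fold higher number from compound 1 to compound 2 (0.84 log units; beyond the scatter), where 1-phenylethyl replaced 4-methylbenzyl. The new change runs the opposite way, from 1-phenylethyl back to a methylbenzyl group, so a fall of similar size is expected in this assay, beyond the scatter. That expectation rests on this single step, and the 3-methylbenzyl group itself has not been measured. The expected step is an at least 5.6-fold lower number from compound 2 to compound 4 (0.74 log units; beyond the scatter). The estimate for compound 4 is 30 ug/mL, with an expected range from 10 ug/mL to 90 ug/mL.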

Compound 4, solubility: >= 205 ug/mL
Compound 4 gave a limit, no number; the forecaster's own chance of this, stated with the estimate: 10%; middle value at least 6.8-fold (0.83 log units) away from the limit.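

In this assay, the high read-out on this aromatic nitrogen turns out not to be confined to 1-phenylethyl: a methylbenzyl group with no defined stereocentre also reaches the upper range. Compound 4 gives >= 205 ug/mL, which is a limit and not a number. With the methyl moved alone, 3-methylphenyl in place of 4-methylphenyl on the saturated chain carbon bound to the aromatic nitrogen gives an at least 8.5-fold higher number from compound 1 to compound 4 (0.93 log units; beyond the scatter), while the step between compound 2 and compound 4 cannot be read, as both values are limits.

On these data alone, the true values of compound 2 and compound 4 remain open, so neither group can be placed ahead of the other. As far as these compounds go, it is also open whether 2-methylbenzyl, 3-methoxybenzyl or unsubstituted benzyl on this nitrogen would read like compound 4 or like compound 1.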